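A few compounds are considered here, and "the series" means these few. Any claim that something is new, unique, unknown or untested is made for them only; others in the source may bear on it.

Measured so far:
Compound 1, `Nc1cccc2c(-c3cccc(NC(=O)c4cccc(C(F)(F)F)c4)c3)ccnc12` — 7900 nM in a functional assay on A375P cells (Homo sapiens) for antiproliferative activity, read by MTT assay, with a stated time of 48 h; a lower number here means a stronger inhibitor, a higher number a weaker inhibitor.
Compound 2, `CC(=O)Nc1cccc2c(-c3cccc(NC(=O)c4cccc(C(F)(F)F)c4)c3)ccnc12` — 8000 nM in this assay.
Compound 3, `CC(=O)Nc1cccc2c(-c3cccc(NC(=O)c4cc(C(F)(F)F)cc(C(F)(F)F)c4)c3)ccnc12` — 1000 nM in this assay.

Compound 2 gives the highest number of the three in this assay. Its nearest neighbour is compound 1, reached by a 1.0-fold higher number from compound 1 to compound 2 (0.01 log units; within the scatter); the two compounds therefore cannot be ranked against each other. Its furthest neighbour is compound 3, reached by an 8.0-fold lower number from compound 2 to compound 3 (0.90 log units; beyond the scatter), a change that sits on the aromatic ring attached to the carbonyl carbon of the amide.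

Compound 4, `CC(=O)Nc1cccc2c(-c3cccc(NC(=O)c4ccc5c(c4)OCCO5)c3)ccnc12`, differs from compound 2 in one place: 2,3-dihydro-1,4-benzodioxin-6-yl in place of 3-(trifluoromethyl)phenyl on a carbonyl carbon. Within the data shown here, of the two measured steps, only the one from compound 2 to compound 3 concerns the same part of the molecule, and it shows that the aryl group on this carbonyl carbon can move the number by a modest amount. Among the measured compounds shown here, no measured compound carries a group of this kind there, and none removes the trifluoromethyl group, so the direction has to be taken from the trend in the one relevant step alone.

Compound 4 is therefore expected to give a number somewhat higher than compound 2, an estimated step of a 1.9-fold higher number from compound 2 to compound 4 (0.27 log units; within the scatter), though the scatter could well hide this. The estimated value for compound 4 in this assay is 15000 nM, with a range of 5000 nM to 50000 nM.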

Compound 4, half-maximal inhibitory concentration: 570 nM
Beside the measured number, compound 4's estimate is 26-fold (1.42 log units) above it; the whole stated range lies above it.
By their numbers in this assay, from the lowest: compounds 4 and 3 (each within the scatter of the next); then compounds 1 and 2 (each within the scatter of the next).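

The change to 2,3-dihydro-1,4-benzodioxin-6-yl on the carbonyl carbon gives a 14-fold lower number from compound 2 to compound 4 (1.15 log units; beyond the scatter) in this assay, so this position tolerates the loss of the trifluoromethyl group and the number still falls by a large step. The earlier compounds had shown a lower number at this position only with a second trifluoromethyl group added, in compound 3 at 1000 nM, whereas compound 4, at 570 nM, carries no fluorine there and lies within the scatter of compound 3, so the two cannot be ranked and a trifluoromethyl group is not needed to reach this level. Nothing available explains why the entering group, with its non-aromatic ring and its oxygen atoms, gives so much lower a number than the group it replaces.

The compounds shown leave open whether the closed non-aromatic ring matters or the oxygen atoms alone suffice, which an open-chain methoxy group or an unsubstituted phenyl group on the same carbonyl carbon would help to separate. They also leave open whether the free amine of compound 1, which cannot be told apart from the acetyl amide of compound 2, would remain equivalent alongside the 2,3-dihydro-1,4-benzodioxin-6-yl group.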